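This account rests on a few compounds, and the source may have more. Where it says the series, first, only, none or still open, it means among the compounds named here.

In a functional assay on HCT-116 cells (Homo sapiens) for inhibition, read by MTT assay, with a stated time of 48 h (on this read-out higher numbers stand for weaker inhibition and lower numbers for stronger inhibition), compound 1 `COc1ccc(-n2c(S)nnc2-c2cc(OC)c(OC)c(OC)c2)cc1` gives > 60000 nM, which is a limit and not a number. Compound 2 `CCSc1nnc(-c2cc(OC)c(OC)c(OC)c2)n1-c1ccc(OC)cc1` gives > 60000 nM, again a limit. Compound 3 `COc1cc(-c2nnc(S)n2-c2ccc(N(C)C)cc2)cc(OC)c1OC` gives > 60000 nM, also a limit. Compound 3 therefore has no true potency on record, and its position is shared by the other two: the limit of > 60000 nM in this assay, at which 3 of the 3 values shown sit.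

Compound 4 `COc1cc(-c2nnc(SCc3ccccc3)n2-c2ccc(N(C)C)cc2)cc(OC)c1OC` differs from compound 3 by benzyl in place of hydrogen on a sulfur. The nearest measured change is ethyl in place of hydrogen on a sulfur, which is a step that the two limits leave unreadable from compound 1 to compound 2. The other measured change, dimethylamino in place of methoxy on an aromatic carbon, is a step that the two limits leave unreadable from compound 1 to compound 3, and compound 4 keeps that dimethylamino group.

Neither change provides a size to carry forward. Within the data shown here, with a step that the two limits leave unreadable from compound 1 to compound 2 as the only guide on the sulfur, there is no measured sign of a gain, and a group as large as benzyl has not been tested on this sulfur. A modest move toward stronger inhibition is expected at best, and a further limit reading would be no surprise. The expected change is an at least 1.7-fold lower number from compound 3 to compound 4 (0.23 log units; that floor lies within the scatter). The estimate for compound 4 is 35000 nM, with an expected range from 6000 nM to 60000 nM.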

Compound 4, half-maximal inhibitory concentration: 54000 nM
Estimate against measurement, compound 4: 1.5-fold (0.19 log units) below; low and high end bracket the measured number.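

In this assay, compound 4 is the first compound shown whose result is a true number and not a limit, so this sulfur is now a place where a change can show up as a reading. The earlier steps shown here, all between limits, cannot be read and could not show this. Replacing hydrogen with benzyl on the sulfur gives an at least 1.1-fold lower number from compound 3 to compound 4 (0.04 log units; that floor lies within the scatter), so the real size of the change is known only as a floor, and that floor does not clear the usual scatter of the assay. Compound 1, compound 2 and compound 3 each remain at a limit, not a number, and the position they share is this: the limit of > 60000 nM in this assay, at which 3 of the 4 values shown sit.

On these data alone, it remains open whether benzyl on this sulfur would also give a true number in the core of compound 1, which carries methoxy where compound 4 keeps dimethylamino. Also open, as far as these compounds go, is how other groups on the same sulfur would read in this assay, such as a longer chain like butyl, a chain ending in a carboxylic acid, or one ending in an amine.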